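This account rests on a few compounds, and the source may have more. Where it says the series, first, only, none or still open, it means among the compounds named here.

The account concerns two measured compounds and one that has not yet been tested, all assessed in a functional assay on PC-3 cells (Homo sapiens) for inhibition, read by MTT assay, with a stated time of 72 h; on this read-out higher numbers stand for weaker inhibition and lower numbers for stronger inhibition. Compound 1, with the structure `CCc1oc([C@H](C)/C=C(\C)[C@H](OC(C)=O)[C@H](C)[C@@H](OC(=O)CC(C)C)[C@@H](C)c2oc([C@@H](C)[C@@H](O)CC)c(C)c(=O)c2C)c(C)c(=O)c1C`, gives 3000 nM in this assay, and this is the lower of the two numbers available. Compound 2, with the structure `CCC(=O)[C@@H](C)c1oc([C@H](C)[C@@H]2O[C@](O)([C@@H](C)c3oc(CC)c(C)c(=O)c3C)[C@@H](C)[C@@H](O)[C@@H]2C)c(C)c(=O)c1C`, gives 82000 nM in this assay, a much higher number, and the gap between compound 1 and compound 2 lies beyond the usual scatter, so compound 1 is the stronger inhibitor of the pair. Going by the values given here, no single-point step between measured compounds exists, so no measured effect of any one change is known.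

Compound 3, with the structure `CCc1oc([C@H](C)/C=C(\C)[C@H](OC(C)=O)[C@H](C)[C@@H](OC(=O)CC(C)C)[C@@H](C)c2oc([C@@H](C)[C@H](CC)OC(C)=O)c(C)c(=O)c2C)c(C)c(=O)c1C`, is built from compound 1 by the change (acetyl in place of hydrogen on an oxygen on a saturated carbon). Since only compound 1 gives a direct reference, and the change touches one hydroxyl of a large shared core, a small shift in this assay is expected, if any beyond the scatter, most likely toward a somewhat higher number. The step from compound 1 to compound 3 is therefore estimated at a 1.5-fold higher number from compound 1 to compound 3 (0.18 log units; within the scatter). For compound 3 the expected value in this assay is 4500 nM, with a range from 1200 nM to 16000 nM.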

Compound 3, half-maximal inhibitory concentration: 7000 nM
The estimate for compound 3 lay 1.6-fold (0.19 log units) below the measured number; low and high end bracket the measured number.
By their numbers in this assay, from the lowest: compound 1; then compound 3; then compound 2.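

In this assay the acetoxy group of compound 3 replaces the hydroxy group of compound 1 within the 2-hydroxy-1-methylbutyl side chain, giving a 2.3-fold higher number from compound 1 to compound 3 (0.37 log units; beyond the scatter) and providing the first measured effect of a single change in this series. The step is modest but beyond the scatter, so the hydrogen on this oxygen on a saturated carbon cannot be exchanged for acetyl without a measurable loss of inhibition, yet compound 3 still gives a value of 7000 nM and the free hydroxy group is therefore not essential for activity in this assay. No independent measurement bears on why the number moves in this direction.

Going by these compounds alone, the single step does not separate the loss of the hydrogen from the arrival of the acetyl group, a question that a methyl ether at the same oxygen would address. It also leaves open how a longer acyl chain such as butanoyl, or an amine in place of the hydroxy group, would read at this position on the shared core.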